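One Stereocentre Flipped: Compound 2 to Compound 3

This account rests on a few compounds, and the source may have more. Where it says the series, first, only, none or still open, it means among the compounds named here.

Compound 1 `COc1c(-c2ccc(C(F)(F)F)cc2Cl)ccc2c1cnn2[C@@H](CC(C)C)c1ccc(C(=O)NCCC(=O)O)cc1`: 87%
Compound 2 `COc1c(-c2ccc(C(F)(F)F)cc2Cl)ccc2nn([C@@H](CC(C)C)c3ccc(C(=O)NCCC(=O)O)cc3)cc12`: 82%

In an ADME assay on microsomes from liver (Mus musculus) for metabolic stability, with a stated time of 10 min, tested at 1 uM (on this read-out higher numbers stand for a more stable compound and lower numbers for a less stable compound), compound 2 gives 82%, within the usual scatter of compound 1 at 87%. Both numbers sit high on the scale. Compound 3 `COc1c(-c2ccc(C(F)(F)F)cc2Cl)ccc2nn([C@H](CC(C)C)c3ccc(C(=O)NCCC(=O)O)cc3)cc12` is the next to be tested. It relates to compound 2 in this way: the two compounds have the same atoms and bonds and differ only in configuration as drawn: 1 of 1 stereo elements differ; a stereocentre at a saturated chain carbon is drawn S in compound 2 and R in compound 3. Going by the values given here, no measured pair shows what such a change does, so the expectation rests on compound 2 at 82%. The expected step of a number 2 percentage points lower from compound 2 to compound 3 (within the scatter) is none beyond the scatter, in no clear direction. For compound 3, the estimated value is 80%, with an expected range of 65% to 92%.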

Compound 3, percent of the compound remaining: 76%
Compound 3: the middle estimate sits 4 percentage points above what was measured, and the stated range covers the measured number.
By their numbers in this assay, from the lowest: compounds 3, 2 and 1 (each within the scatter of the next, the first and the last beyond it).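

In this assay, flipping the single stereocentre at the saturated chain carbon gives a number 6 percentage points lower from compound 2 to compound 3 (within the scatter). Going by these compounds alone, this is the first measured pair to isolate configuration at this position, and it shows no effect that can be told apart from the scatter, with both drawn forms reading high on the scale. The comparison is a clean one, resting on a single structural difference: the fact that compounds 2 and 3 differ only in the configuration as drawn

Still open, from the compounds shown here alone, is whether the same holds on the core of compound 1. Also open, going by these compounds, is whether configuration would matter with an amine in place of the carboxylic acid.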